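A few compounds are considered here, and "the series" means these few. Any claim that something is new, unique, unknown or untested is made for them only; others in the source may bear on it.

Of the compounds shown here, three have been tested so far in a functional assay on A-427 cells (Homo sapiens) for cytotoxicity, read by colorimetric assay and MTT assay; on this read-out lower numbers stand for stronger inhibition and higher numbers for weaker inhibition. Compound 1 `COc1cccc2cc(-c3ccccc3)c(O)nc12` gives 10000 nM, and compound 2 `COc1cc(OC)c2cc(-c3ccccc3)c(O)nc2c1` gives 10000 nM. Compound 3 `CCN(CC)C(=O)Cn1c(=O)c(-c2ccc(OC)cc2)cc2c(OC)cc(OC)cc21` gives 10000 nM, which places it level with the other two, so the numbers do not separate these three compounds.

Compound 4 `COc1ccc(-c2cc3c(OC)cc(OC)cc3n(CCC#N)c2=O)cc1` differs from compound 3 in one place: cyanomethyl in place of diethylcarbamoyl on a saturated chain carbon bound to an aromatic nitrogen. In words, cyanomethyl stands in place of diethylcarbamoyl on a saturated chain carbon bound to an aromatic nitrogen. Cut one bond further out, the same difference reads (diethylcarbamoyl)methyl to 2-cyanoethyl.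

For the measured compounds named here, no pair of tested compounds differs in just one place, so the data offer no direct measure of how much a single change can move this read-out. Going by the values given here, the only guide is the flat picture so far, with compound 3 at 10000 nM and the other two level with it. A shift in either direction remains possible, but no step beyond the usual scatter is expected in this assay. The estimated change, no change at the digits printed from compound 3 to compound 4 (within the scatter), is therefore expected to be negligible. For compound 4 the estimate is 10000 nM, with an expected range from 3000 nM to 20000 nM.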

Compound 4, half-maximal inhibitory concentration: 10000 nM
Beside the measured number, compound 4's estimate shows no gap at the digits printed, within the range that was stated.
By their numbers in this assay, from the lowest: compounds 1, 2, 3 and 4 (each within the scatter of the next).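

The exchange of diethylcarbamoyl for cyanomethyl on a saturated chain carbon bound to an aromatic nitrogen gives the first direct measure of a single change in this assay, and it reads no change at the digits printed from compound 3 to compound 4 (within the scatter). At this place, then, a group of 7 heavy atoms with an amide-type carbonyl can give way to one of 3 heavy atoms ending in a nitrile without moving the read-out, and both groups count 1 hydrogen-bond acceptor and 0 donors. No measurement here accounts for why the two groups read alike.

For the compounds shown here, this single step speaks for only one pair of groups at one place, so it remains open whether an amine, a carboxylic acid or a longer chain on the same nitrogen would shift the number in this assay. Also open is whether a change elsewhere, such as a chlorine atom in place of a methoxy group, would move a read-out that has so far stayed level across all the compounds shown.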